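A few compounds are considered here, and "the series" means these few. Any claim that something is new, unique, unknown or untested is made for them only; others in the source may bear on it.

Of the compounds shown here, three that share one core have been tested in a functional assay on HepG2 cells (Homo sapiens) for cytotoxicity, read by MTT assay, with a stated time of 48 h; on this read-out higher numbers stand for weaker inhibition and lower numbers for stronger inhibition. Compound 3 `COc1cc(C(=O)C2Sc3nnc(-c4cc(OC)c(OC)c(OC)c4)n3NC2c2cccs2)cc(OC)c1OC` gives a result reported only as a limit, > 100000 nM. Compound 1 `COc1cc(C(=O)C2Sc3nnc(-c4cc(OC)c(OC)c(OC)c4)n3NC2c2ccco2)cc(OC)c1OC` likewise gives only a limit, > 100000 nM. Compound 2 `COc1cc(-c2nnc3n2NC(c2cccs2)C(C(=O)c2ccccc2)S3)cc(OC)c1OC` also gives only a limit, > 100000 nM. Compound 1 differs from compound 3 by furan-2-yl in place of thiophen-2-yl on a saturated ring carbon, and the step in this assay is a step that the two limits leave unreadable from compound 3 to compound 1. Compound 2 differs from compound 3 by phenyl in place of 3,4,5-trimethoxyphenyl on a carbonyl carbon, and the step is a step that the two limits leave unreadable from compound 2 to compound 3. Compound 4 `COc1cc(-c2nnc3n2NC(c2ccco2)C(C(=O)c2ccccc2)S3)cc(OC)c1OC` has not yet been measured; it differs from compound 2 by furan-2-yl in place of thiophen-2-yl on a saturated ring carbon, the same kind of change as that from compound 3 to compound 1, except that here the place is next to the ring atom that bears a benzoyl group rather than a large group. Because all three results sit at the limit of > 100000 nM in this assay, at which 3 of the 3 values shown sit, the step from compound 2 to compound 4 is expected to be a step that the limit leaves unreadable from compound 2 to compound 4. Compound 4 is estimated to come out near 150000 nM, most likely again as a limit, with a plausible range from 50000 nM to 500000 nM.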

Compound 4, half-maximal inhibitory concentration: 90900 nM
Compound 4: middle estimate off by 1.7-fold (0.22 log units), on the high side; low and high end bracket the measured number.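

In this assay, furan-2-yl in place of thiophen-2-yl on a saturated ring carbon gives an at least 1.1-fold lower number from compound 2 to compound 4 (0.04 log units; that floor lies within the scatter), and phenyl in place of 3,4,5-trimethoxyphenyl on a carbonyl carbon gives an at least 1.1-fold lower number from compound 1 to compound 4 (0.04 log units; that floor lies within the scatter). Neither result shows a change larger than the usual scatter, and the steps among compounds 1, 2 and 3 cannot be read. The swap from thiophen-2-yl to furan-2-yl therefore cannot be compared between the two cores, and it is not shown to carry over from one to the other: the limit of > 100000 nM in this assay, at which 3 of the 4 values shown sit.

The compounds shown leave open how a group of another kind on that saturated ring carbon, such as an amine or a carboxylic acid, would behave. They also leave open whether any such replacement would give a number well clear of that limit.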